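Biaryl series: lipophilicity step from compound 3 to compound 4

The compounds below may be only part of what the source reports. "The series", "measured", "known", "first", "only" and "open" are said of these compounds alone.

Measured compounds:
compound 1 `CC[C@@H](Nc1c(C#N)c(-c2ccc(-c3cccc(OC)c3)cc2)nc2cnccc12)C(N)=O`: 2.7
compound 2 `CC[C@@H](Nc1c(C#N)c(-c2ccc(-c3ccccc3C(C)C)cc2)nc2cnccc12)C(N)=O`: 3.5
compound 3 `CC[C@@H](Nc1c(C#N)c(-c2ccc(-c3ccccc3COC)cc2)nc2cnccc12)C(N)=O`: 2.6

In a physicochemical assay for lipophilicity, read by HPLC, at pH 7.5 (a higher number here means a more lipophilic compound, a lower number a more polar compound), compound 3 gives 2.6, the lowest of the three numbers; against compound 1 it reads a number 0.10 log units lower from compound 1 to compound 3 (within the scatter), against compound 2 a number 0.90 log units lower from compound 2 to compound 3 (beyond the scatter). Compound 4 `CC[C@@H](Nc1c(C#N)c(-c2ccc(-c3ccccc3C)cc2)nc2cnccc12)C(N)=O` is not yet measured. The change is hydrogen in place of methoxy on a saturated chain carbon bound to an aromatic carbon. The bearing step is a number 0.90 log units lower from compound 2 to compound 3 (beyond the scatter), a modest move; the step from methoxymethyl to methyl removes the methoxy that entered there while leaving a smaller group than isopropyl, so compound 4 is expected to land between compound 3 and compound 2, with a step of a number 0.60 log units higher from compound 3 to compound 4 (beyond the scatter) upward beyond the scatter. The estimate for compound 4 in this assay is 3.2, range 2.9 to 3.5.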

Compound 4, distribution coefficient: 3
Estimate against measurement, compound 4: 0.20 log units above; low and high end bracket the measured number.
By their numbers in this assay, from the lowest: compounds 3, 1 and 4 (each within the scatter of the next, the first and the last beyond it); then compound 2.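

In this assay the loss of the methoxy reads a number 0.40 log units higher from compound 3 to compound 4 (beyond the scatter) and methyl in place of isopropyl reads a number 0.50 log units lower from compound 2 to compound 4 (beyond the scatter) so that methoxymethyl, methyl and isopropyl at this place now stand apart from one another in compounds 3, 4 and 2. The 2-methylphenyl group set against 3-methoxyphenyl reads a number 0.30 log units higher from compound 1 to compound 4 (within the scatter) and so does not separate those two compounds. Going by these compounds alone, no evidence accompanies these steps.

As far as these compounds go, whether an amine, a carboxylic acid or a longer chain in place of the methyl would extend this order remains open.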